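Benzyl for pyridinyl on an isoxazole-fused acid

The compounds below may be only part of what the source reports. "The series", "measured", "known", "first", "only" and "open" are said of these compounds alone.

Compound 1 `CNC(=O)c1ccc2noc(-c3ccccc3)c2c1`: 6830 nM
Compound 2 `O=C(O)c1ccc2noc(-c3ccc(-c4ccncc4)cc3)c2c1`: 670 nM

In an assay for inhibition of inositol hexakisphosphate kinase 3 (Homo sapiens), read by colorimetric assay, coupled enzyme assay and malachite green, with a stated time of 120 min, in the presence of a further agent that is not named here (a lower number here means a stronger inhibitor, a higher number a weaker inhibitor), compound 2 gives 670 nM, the lowest of the two numbers; compound 1 gives 6830 nM, a gap beyond the scatter. Compound 3 `O=C(O)c1ccc2noc(-c3ccc(Cc4ccccc4)cc3)c2c1` differs from compound 2 in one place: benzyl in place of pyridin-4-yl on an aromatic carbon. For the measured compounds named here, no comparable step between measured compounds exists here, so the size is estimated from compound 2 alone. A small shift toward a higher number, close to the scatter, is expected, as a 1.8-fold higher number from compound 2 to compound 3 (0.25 log units; within the scatter). For compound 3 the expected value in this assay is 1200 nM, within 350 nM to 4500 nM.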

Compound 3, half-maximal inhibitory concentration: 1290 nM
Compound 3: middle estimate off by 1.1-fold (0.03 log units), on the low side, and the stated range covers the measured number.
By their numbers in this assay, from the lowest: compounds 2 and 3 (each within the scatter of the next); then compound 1.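

Placing benzyl in place of pyridin-4-yl gives a 1.9-fold higher number from compound 2 to compound 3 (0.28 log units; within the scatter) in this assay, so this position, on an aromatic carbon and para to a large group, accepts either ring without a difference that can be told from the scatter. The ring nitrogen and its hydrogen-bond acceptor, both lost in this change, are therefore not needed to keep the number in this range. Nothing available explains why the two groups read alike.

On these data alone, whether a much smaller group, such as methoxy, or a basic group, such as an aminomethyl, would also be accepted here remains open. So does whether a longer chain between the two rings would hold the number.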